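The compounds below may be only part of what the source reports. "The series", "measured", "known", "first", "only" and "open" are said of these compounds alone.

The measured compounds:

compound 1, `COc1ccc(NCCNC(=O)[C@H](CC(C)C)NC(=O)c2cccc(OC)c2)cc1`: 470 nM
compound 2, `CC(C)C[C@H](NC(=O)OCc1ccccc1)C(=O)NCCNc1ccc(OCCn2ccnc2)cc1`: 5700 nM
compound 3, `CC(C)C[C@H](NC(=O)OCc1ccccc1)C(=O)NCCNc1ccc(OCC2CC2)cc1`: 2800 nM

All three were tested in an assay on isolated protein for inhibition of cathepsin S (Homo sapiens); on this read-out lower numbers stand for stronger inhibition and higher numbers for weaker inhibition. Compound 1 has the lowest number of the three, so it is the strongest inhibitor here; compound 3 comes nearest, and compound 2 lies furthest away. For the measured compounds named here, the only change between two measured compounds that differ in one place is the one from compound 2 to compound 3, a cyclopropyl in place of (1H-imidazol-1-yl)methyl on a saturated chain carbon bound to an oxygen on an aromatic ring, which gave a 2.0-fold lower number from compound 2 to compound 3 (0.31 log units; beyond the scatter).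

The new compound 4, `COc1ccc(NCCNC(=O)[C@H](CC(C)C)NC(=O)c2cc3ccccc3[nH]2)cc1`, differs from compound 1 in a single place:

1H-indol-2-yl in place of 3-methoxyphenyl on a carbonyl carbon

Going by the values given here, no measured step touches this part of the molecule: the step from compound 2 to compound 3 alters a different end of the shared core, so it cannot guide the direction here. With nothing to lean on, the expected step of a 1.6-fold lower number from compound 1 to compound 4 (0.19 log units; within the scatter) is small, in either direction. Compound 4 is therefore estimated at 300 nM in this assay, within a range of 60 nM to 1500 nM.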

Compound 4, half-maximal inhibitory concentration: 160 nM
For compound 4 the middle estimate is 1.9-fold (0.27 log units) above the measured one, and the stated range covers the measured number.
By their numbers in this assay, from the lowest: compound 4; then compound 1; then compound 3; then compound 2.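

In this assay, the swap of 3-methoxyphenyl for 1H-indol-2-yl on the carbonyl carbon gave a 2.9-fold lower number from compound 1 to compound 4 (0.47 log units; beyond the scatter), which shows that the number responds to the group at this position. The change replaces one six-membered aromatic ring of carbon only with a five-membered and a six-membered aromatic ring, and it exchanges a hydrogen-bond acceptor for a hydrogen-bond donor, so this single step cannot separate these differences. No measurement at hand explains the lower number.

On these data alone, whether the hydrogen on the indole nitrogen plays any part remains open, and 1-methyl-1H-indol-2-yl or benzofuran-2-yl on the same carbonyl carbon would address that question. As far as these compounds go, it is also open whether the six-membered ring of the indole is needed, which the smaller 1H-pyrrol-2-yl would probe.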